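The source may report more compounds than this note shows. Statements on the series, on what has been measured and on what is new or still open speak of the compounds shown alone.

Compound 1 `CS(=O)(=O)c1ccc(C(=O)N2CCC(C(=O)N3CCc4ccccc43)CC2)cc1[N+](=O)[O-]`: in an assay on isolated protein for inhibition of thyroid hormone receptor alpha (Homo sapiens), read by fluorescence polarization (a higher number here means a weaker inhibitor, a lower number a stronger inhibitor), compound 1 gives > 60000 nM, which is a limit of the assay and not a number.
Compound 2 `CN(Cc1ccccc1F)C(=O)C1CCN(C(=O)c2ccc(S(C)(=O)=O)c([N+](=O)[O-])c2)CC1`: in this assay compound 2 gives > 60000 nM, again only a limit.
Compound 3 `CN1CCN(C(=O)C2CCN(C(=O)c3ccc(S(C)(=O)=O)c([N+](=O)[O-])c3)CC2)CC1`: in this assay compound 3 gives > 60000 nM, again only a limit.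

All three compounds share one core and differ only in the group attached to a single carbonyl carbon. Compound 3 stands exactly where the other two stand, at the limit of > 60000 nM in this assay, at which 3 of the 3 values shown sit, so none of the three can be called stronger or weaker than another. The three measured steps, a step that the two limits leave unreadable from compound 1 to compound 2, a step that the two limits leave unreadable from compound 1 to compound 3 and a step that the two limits leave unreadable from compound 2 to compound 3, have limits at both ends and therefore show no size in either direction.

Compound 4 `CC(C)N(C(=O)C1CCN(C(=O)c2ccc(S(C)(=O)=O)c([N+](=O)[O-])c2)CC1)C(C)C` has not yet been measured. The change from compound 3 is diisopropylamino in place of 4-methylpiperazin-1-yl on a carbonyl carbon. The measured steps all swap the group on this same carbonyl carbon, and every one of them left the value at the limit, so they bear on the new change without giving it a readable size. The step that the limit leaves unreadable from compound 3 to compound 4 is therefore expected to stay within the scatter, with compound 4 most likely again at the limit. Compound 4 is estimated to give about 90000 nM in this assay, in a range from 25000 nM to 300000 nM.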

Compound 4, half-maximal inhibitory concentration: > 60000 nM
Compound 4 gave a limit, no number (the forecaster's own chance of this, stated with the estimate: 85%); the middle value is on the limit's open side.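

Compound 4 gives only a limit, as do compound 1, compound 2 and compound 3, so the steps from compound 4 to each of them cannot be read and the four cannot be ranked: the limit of > 60000 nM in this assay, at which 4 of the 4 values shown sit. The compounds shown leave open whether any group on this carbonyl carbon, or any change elsewhere on the shared core, gives a readable value in this assay.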